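Working notes: swapping the sugar for a diol

The compounds below may be only part of what the source reports. "The series", "measured", "known", "first", "only" and "open" are said of these compounds alone.

In a functional assay on SH-SY5Y cells (Homo sapiens) for cytotoxicity, read by MTT assay, with a stated time of 72 h (a lower number here means a stronger inhibitor, a higher number a weaker inhibitor), compound 1 `CC1(C)OC[C@@H](Cn2cc(Cn3c4c(c5ccccc53)C(=O)c3c[n+]([O-])c5ccccc5c3C4=O)nn2)O1` gives only a limit, > 1000 nM. Compound 2 `CCCN1CCN(CCCCn2c3c(c4ccccc42)C(=O)c2c[n+]([O-])c4ccccc4c2C3=O)CC1` gives 3970 nM and compound 3 `O=C1c2c[n+]([O-])c3ccccc3c2C(=O)c2c1c1ccccc1n2Cc1cn([C@@H]2O[C@H](CO)[C@@H](O)[C@H](O)[C@H]2O)nn1` gives 880 nM, the lower of these two numbers. Compound 4 `O=C1c2c[n+]([O-])c3ccccc3c2C(=O)c2c1c1ccccc1n2Cc1cn(C[C@@H](O)CO)nn1` changes compound 3 at one place: 2,3-dihydroxypropyl in place of 3,4,5-trihydroxy-6-(hydroxymethyl)oxan-2-yl on an aromatic nitrogen, on an aromatic nitrogen of a five-membered aromatic ring with 3 nitrogen. Within the data shown here, one measured step bears on this nitrogen: an at least 1.1-fold lower number from compound 1 to compound 3 (0.05 log units; that floor lies within the scatter). That step ends on compound 3 but starts from a limit, so it fixes only a floor, and the floor is small. No shift beyond the scatter is therefore expected in this assay, and the expected change is a 1.1-fold higher number from compound 3 to compound 4 (0.06 log units; within the scatter). For compound 4 the estimated value is 1000 nM, with an expected range from 350 nM to 3000 nM.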

Compound 4, half-maximal inhibitory concentration: > 500 nM
Compound 4: no number, only a limit (the forecaster's own chance of this, stated with the estimate: 25%); the middle value is on the limit's open side.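

Among these compounds, compound 4 gives > 500 nM as a limit, so no step to it from compound 1, compound 2 or compound 3 can be read. The compounds shown leave open how far 2,3-dihydroxypropyl in place of 3,4,5-trihydroxy-6-(hydroxymethyl)oxan-2-yl moves the number.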